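From (cyclopropylcarbonyl)amino to (3,5-dichloropyridin-2-yl)oxy

The source may report more compounds than this note shows. Statements on the series, on what has been measured and on what is new or still open speak of the compounds shown alone.

Of the compounds shown here, two have been measured so far. In an assay for inhibition of inositol hexakisphosphate kinase 3 (Homo sapiens), read by colorimetric assay, coupled enzyme assay and malachite green, with a stated time of 120 min, in the presence of a further agent that is not named here (a lower number here means a stronger inhibitor, a higher number a weaker inhibitor), compound 1 `CNC(=O)/C=C/c1ccc2noc(-c3ccccc3)c2c1` gives 42600 nM, while compound 2 `O=C(O)c1ccc2noc(-c3cccc(NC(=O)C4CC4)c3)c2c1` gives 2810 nM, the lower of the two numbers and thus the stronger inhibitor of the pair. Compound 3 `O=C(O)c1ccc2noc(-c3cccc(Oc4ncc(Cl)cc4Cl)c3)c2c1` is not yet measured; it differs from compound 2 by (3,5-dichloropyridin-2-yl)oxy in place of (cyclopropylcarbonyl)amino on an aromatic carbon. Within the data shown here, no measured pair shows this change, so the direction is uncertain, and the step from compound 2 to compound 3 is expected to be a 1.1-fold lower number from compound 2 to compound 3 (0.05 log units; within the scatter), within the usual scatter. Compound 3 is therefore estimated at 2500 nM in this assay, with a range from 700 nM to 9000 nM.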

Compound 3, half-maximal inhibitory concentration: 3090 nM
Compound 3: middle estimate off by 1.2-fold (0.09 log units), on the low side; low and high end bracket the measured number.
By their numbers in this assay, from the lowest: compounds 2 and 3 (each within the scatter of the next); then compound 1.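

In this assay, placing (3,5-dichloropyridin-2-yl)oxy instead of (cyclopropylcarbonyl)amino on this aromatic carbon gives a 1.1-fold higher number from compound 2 to compound 3 (0.04 log units; within the scatter). Two quite different groups therefore read alike here: one brings a six-membered aromatic ring and no hydrogen-bond donor, the other a three-membered ring and a hydrogen-bond donor. Nothing available explains why the two read alike. From the compounds shown here alone, it remains open whether a simple amine or a methoxy group on this carbon would give a similar number. Going by these compounds, it also remains open whether a hydrogen there would do the same.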